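Difluorophenyl on the triazole nitrogen of a trifluoromethyl amide

The source may report more compounds than this note shows. Statements on the series, on what has been measured and on what is new or still open speak of the compounds shown alone.

Of the compounds shown here, two have numbers so far. Compound 1 `Cc1c(C(=O)Nc2ccc(Oc3ccnc4[nH]ccc34)c(F)c2)nnn1-c1ccc(F)c(F)c1` gives 6540 nM in a functional assay on PC-3 cells (Homo sapiens) for cytotoxicity, read by MTT assay, with a stated time of 72 h; a lower number here means a stronger inhibitor, a higher number a weaker inhibitor. Compound 2 `O=C(Nc1ccc(Oc2ccnc3[nH]ccc23)c(F)c1)c1nnn(-c2ccccc2)c1C(F)(F)F` gives 2320 nM in this assay, the lowest of the two numbers; the number for compound 1 is higher, a gap beyond the usual scatter. No single change links compound 1 to compound 2, so only their two values stand side by side.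

Compound 3 `O=C(Nc1ccc(Oc2ccnc3[nH]ccc23)c(F)c1)c1nnn(-c2ccc(F)c(F)c2)c1C(F)(F)F` has not been measured. It differs from compound 2 in one place: 3,4-difluorophenyl in place of phenyl on an aromatic nitrogen. Among the measured compounds shown here, no measured pair in this set isolates the effect of 3,4-difluorophenyl in place of phenyl on that aromatic nitrogen, so there is no step on record from which to read its size. The writer therefore expects for compound 3 a step of a 1.3-fold higher number from compound 2 to compound 3 (0.11 log units; within the scatter) that may well stay within the scatter, with no clear direction. Compound 3 is estimated at 3000 nM, with a plausible range from 1200 nM to 8000 nM, pending the measurement.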

Compound 3, half-maximal inhibitory concentration: 2480 nM
Beside the measured number, compound 3's estimate is 1.2-fold (0.08 log units) above it; the range from low to high includes it.
By their numbers in this assay, from the lowest: compounds 2 and 3 (each within the scatter of the next); then compound 1.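

In this assay, 3,4-difluorophenyl in place of phenyl on the aromatic nitrogen gives a step that stays within the scatter (a 1.1-fold higher number from compound 2 to compound 3 (0.03 log units; within the scatter)), so with a trifluoromethyl group on the next ring atom, these numbers separate the two aryl groups at this position by no more than repeated measurements would. Compound 3 also supplies the first single-change link to compound 1: with 3,4-difluorophenyl on the nitrogen in both, trifluoromethyl in place of methyl on an aromatic carbon gives a modest step beyond the scatter (a 2.6-fold lower number from compound 1 to compound 3 (0.42 log units; beyond the scatter)), which places the only clear difference in this set at that carbon rather than at the nitrogen. No accompanying measurement explains either step.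

The compounds shown leave open whether the near-equal values for phenyl and 3,4-difluorophenyl would persist with methyl on the carbon, since that comparison would need the phenyl compound carrying methyl. They also leave open how a pyridyl or benzyl group on the nitrogen, or an ethyl or cyclopropyl group on the carbon, would read in this assay.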